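From 2-fluorophenyl to 2-methoxyphenyl in this series

The source may report more compounds than this note shows. Statements on the series, on what has been measured and on what is new or still open speak of the compounds shown alone.

Within the data shown here, in a functional assay for inhibition, with Homo sapiens as the target (on this read-out lower numbers stand for tighter binding and higher numbers for weaker binding), compound 1 (`Cc1ccc(OC(C)(C)C2OCC(C/C=C\CCC(=O)O)C(c3cccnc3)O2)cc1`) gives 631 nM and compound 2 (`CC(C)(Oc1ccccc1F)C1OCC(C/C=C\CCC(=O)O)C(c2cccnc2)O1`) gives 166 nM, the lowest of the two numbers so far. Compound 3 (`COc1ccccc1OC(C)(C)C1OCC(C/C=C\CCC(=O)O)C(c2cccnc2)O1`) has methoxy in place of fluoro on an aromatic carbon, ortho to a large group: methoxy in place of fluoro on an aromatic carbon. Among the measured compounds shown here, only one measured step bears on this change, and only indirectly: a 3.8-fold lower number from compound 1 to compound 2 (0.58 log units; beyond the scatter), with 2-fluorophenyl in place of 4-methylphenyl. That step was modest but beyond the scatter. For the measured compounds named here, no measured pair isolates methoxy against fluoro, so its size serves only as an upper guide. A small move toward a higher number in this assay is expected, possibly not beyond the scatter. The expected step is a 1.4-fold higher number from compound 2 to compound 3 (0.14 log units; within the scatter). For compound 3 the estimated value is 230 nM, with an expected range of 90 nM to 600 nM.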

Compound 3, dissociation constant: 224 nM
For compound 3 the middle estimate is 1.0-fold (0.01 log units) above the measured one; low and high end bracket the measured number.
By their numbers in this assay, from the lowest: compounds 2 and 3 (each within the scatter of the next); then compound 1.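

In this assay methoxy in place of fluoro on this aromatic carbon, ortho to a large group, gives a 1.3-fold higher number from compound 2 to compound 3 (0.13 log units; within the scatter) and so going from one heavy atom to two, with one hydrogen-bond acceptor entering, does not move the read-out beyond the scatter. With 2-methoxyphenyl in place of 4-methylphenyl there is a 2.8-fold lower number from compound 1 to compound 3 (0.45 log units; beyond the scatter) and this shows that the step away from compound 1 is not confined to the 2-fluorophenyl group of compound 2. No supporting data accompany these numbers to explain them.

The compounds shown leave open whether the lower numbers go with the place on the ring or with the group itself. They also leave open how a 2-methylphenyl, 2-chlorophenyl or 2-aminophenyl group would read here.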